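Agonist series: heteroaryl alkyne variation at the receptor

A few compounds are considered here, and "the series" means these few. Any claim that something is new, unique, unknown or untested is made for them only; others in the source may bear on it.

Measured compounds in an in vitro functional assay on 1321-N1 cells for agonist activity at Free fatty acid receptor 1 (Homo sapiens), read by fluorescence, spectrophotometry and calcium flux; on this read-out higher numbers stand for an effect only at larger amounts of compound and lower numbers for an effect already at smaller amounts:
compound 1 `Cc1ccccc1-c1cc(C#Cc2ccc(CCC(=O)O)cc2)ccn1`, compound 1 gives 1070 nM
compound 2 `O=C(O)CCc1ccc(C#Cc2cncs2)cc1`, compound 2 gives 3890 nM
compound 3 `Cc1ccsc1C#Cc1ccc(CCC(=O)O)cc1`, compound 3 gives 75.9 nM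

Compound 3 holds the lowest number of the three. Its nearest neighbour is compound 1 and the furthest is compound 2; both gaps are beyond the scatter, so compound 3 stands as the most potent of the measured set.

The next compound is compound 4 `O=C(O)CCc1ccc(C#Cc2ccncc2)cc1`. It differs from compound 3 in one place: pyridin-4-yl in place of 3-methylthiophen-2-yl on a triple-bonded carbon.

For the measured compounds named here, the only measured step that touches the same place is a 51-fold lower number from compound 2 to compound 3 (1.71 log units; beyond the scatter), where a five-membered ring with a nitrogen and no methyl was exchanged for the 3-methylthiophen-2-yl group. Compound 4 moves in the opposite sense: a ring with a nitrogen and no methyl again replaces the 3-methylthiophen-2-yl group, although the ring is six-membered rather than five-membered. Compound 1, which carries a larger substituted pyridin-4-yl group in this place, also sits well above compound 3. A higher number than compound 3 is therefore expected for compound 4 in this assay, by a step of about a 33-fold higher number from compound 3 to compound 4 (1.52 log units; beyond the scatter).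

Compound 4 is estimated at 2500 nM, with a range from 500 nM to 12000 nM.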

Compound 4, half-maximal effective concentration: 4070 nM
Beside the measured number, compound 4's estimate is 1.6-fold (0.21 log units) below it, within the range that was stated.
By their numbers in this assay, from the lowest: compound 3; then compound 1; then compounds 2 and 4 (each within the scatter of the next).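

In this assay, pyridin-4-yl and 1,3-thiazol-5-yl on the triple-bonded carbon cannot be told apart (a 1.0-fold higher number from compound 2 to compound 4 (0.02 log units; within the scatter)), so the difference between a six-membered and a five-membered ring does not separate these two nitrogen-containing groups. Against that level, 3-methylthiophen-2-yl stands out, and the large step (a 54-fold higher number from compound 3 to compound 4 (1.73 log units; beyond the scatter)) now gives a second exchange at this position that ends far from compound 3, so the low number is not tied to the 1,3-thiazol-5-yl comparison alone. On the pyridin-4-yl ring, the step of hydrogen for 2-methylphenyl on an aromatic carbon (a 3.8-fold higher number from compound 1 to compound 4 (0.58 log units; beyond the scatter)) is modest, which shows that the ring can carry that substituent without a higher number in this assay.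

The compounds shown leave open whether the low number of compound 3 follows the methyl group or the sulfur-containing ring, a question that an unsubstituted thiophen-2-yl group or a 2-methylphenyl group on the triple-bonded carbon would address. No measurement is at hand that explains the difference between these groups.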